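Replacing bromine with a dimethylisoxazole on a coumarin series

The compounds below may be only part of what the source reports. "The series", "measured", "known", "first", "only" and "open" are said of these compounds alone.

Of the compounds shown here, three that share one core have been measured in an ADME assay on A549 cells (Homo sapiens) for cytotoxicity, read by CellTiter-Glo; on this read-out higher numbers stand for lower toxicity in this test and lower numbers for higher toxicity in this test. Compound 1 `Cc1c(Cc2ccc(C(C)(C)C)cc2)c(=O)oc2cc(OCC(O)CN3CCC(C(N)=O)CC3)ccc12` gives 14700 nM. Compound 2 `Cc1c(Cc2ccc(Br)cc2)c(=O)oc2cc(OCC(O)CN3CCC(C(N)=O)CC3)ccc12` reaches only the limit of > 100000 nM, so its position is known as a bound rather than a number (the limit of > 100000 nM in this assay, at which 1 of the 3 values shown sits). Compound 3 `Cc1c(Cc2ccc(F)cc2Cl)c(=O)oc2cc(OCC(O)CN3CCC(C(N)=O)CC3)ccc12` gives 90800 nM. The step of an at least 6.8-fold higher number from compound 1 to compound 2 (0.83 log units; beyond the scatter) and the step of a 6.2-fold higher number from compound 1 to compound 3 (0.79 log units; beyond the scatter) both move toward lower toxicity in this assay, while the step of an at least 1.1-fold lower number from compound 2 to compound 3 (0.04 log units; that floor lies within the scatter) stays within the scatter.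

Compound 4 `Cc1noc(C)c1-c1ccc(Cc2c(C)c3ccc(OCC(O)CN4CCC(C(N)=O)CC4)cc3oc2=O)cc1` has not yet been measured. Compared with compound 2 it carries 3,5-dimethyl-1,2-oxazol-4-yl in place of bromo on an aromatic carbon, on an aromatic carbon of a six-membered aromatic ring of carbon only, para to a large group. Among the measured compounds shown here, none of the measured steps brings in a heteroaromatic ring at this position; the closest guidance is that the two halogenated compounds sit well above compound 1, and the new group is bulkier than bromine. Compound 4 is therefore expected to show the step of an at least 2.5-fold lower number from compound 2 to compound 4 (0.39 log units; beyond the scatter), its value estimated at 40000 nM with a range from 10000 nM to 100000 nM.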

Compound 4, half-maximal cytotoxic concentration: 36900 nM
Beside the measured number, compound 4's estimate is 1.1-fold (0.04 log units) above it; the range from low to high includes it.
By their numbers in this assay, from the lowest: compound 1; then compound 4; then compound 3. At a limit, above all of these: compound 2.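

In this assay, putting 3,5-dimethyl-1,2-oxazol-4-yl on this aromatic carbon gives an at least 2.7-fold lower number from compound 2 to compound 4 (0.43 log units; beyond the scatter), which shows that a five-membered aromatic ring with 2 hetero atoms at this place can lower the number relative to bromo. The same group still gives a 2.5-fold higher number from compound 1 to compound 4 (0.40 log units; beyond the scatter), so the two non-halogen groups at this place, tert-butyl and 3,5-dimethyl-1,2-oxazol-4-yl, do not read alike, and the new ring leaves the number clearly higher than tert-butyl does. Compound 2 stands at a limit and not at a number, so the step from bromo fixes only a floor: the limit of > 100000 nM in this assay, at which 1 of the 4 values shown sits.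

The compounds shown leave open how far the number really falls from bromo, and whether the two methyl groups on the new ring play any part. They also leave open where a pyridine ring, a plain phenyl ring or a carboxylic acid at this place would fall.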